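Swapping chloro for fluoro in compound 3

The compounds below may be only part of what the source reports. "The series", "measured", "known", "first", "only" and "open" are said of these compounds alone.

- compound 1 (`COC(=O)/C(=C/c1ccccc1)CN1C(=O)[C@@H](OC)[C@H]1c1ccc(Cl)cc1`): 37900 nM
- compound 2 (`CCOC(=O)/C(=C/c1ccccc1)CN1C(=O)[C@@H](OC)[C@H]1c1ccc(Cl)cc1`): "not toxic" (no number reported)
- compound 3 (`COC(=O)/C(=C/c1ccccc1)CN1C(=O)[C@@H](OC)[C@H]1c1cccc(Cl)c1`): "not toxic" (no number reported)

These three compounds share one core and were tested in an ADME assay on cells (Epithelial cell, Homo sapiens) for antiproliferative activity, read by MTT assay, with a stated time of 48 h (a higher number here means a weaker inhibitor, a lower number a stronger inhibitor), to see how strongly each one slows cell growth. Compound 3 has no single number, since it is reported only as "not toxic" (no number reported) in this test, and compound 2 is the one other entry of that kind.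

The next compound, compound 4 (`COC(=O)/C(=C/c1ccccc1)CN1C(=O)[C@@H](OC)[C@H]1c1cccc(F)c1`), differs from compound 3 at a single place: fluoro in place of chloro on an aromatic carbon. In words, this is fluoro in place of chloro on an aromatic carbon, or 3-chlorophenyl to 3-fluorophenyl.

Among the compounds with values here, no measured pair here shows what such a swap does. With compound 3 reported as "not toxic" (no number reported) and compound 1 at 37900 nM as the only figure available, no large step in either direction is expected in this assay and compound 4 may also receive no number. Compound 4 is expected to read 50000 nM with an estimated range from 20000 nM to 120000 nM if a number is reported at all.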

Compound 4, half-maximal inhibitory concentration: 38500 nM
Beside the measured number, compound 4's estimate is 1.3-fold (0.11 log units) above it, and the stated range covers the measured number.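

In this assay compound 4 gives 38500 nM with fluoro on this aromatic carbon, whereas compound 3, with chloro in the same place, is reported as not toxic with no number, so the step between these two cannot be read. Within the data shown here, the one step that can be read, a 1.0-fold higher number from compound 1 to compound 4 (0.01 log units; within the scatter), changes both the halogen and its place on the ring, as 3-fluorophenyl stands in place of 4-chlorophenyl, so it does not isolate either change. No measurement at hand explains why one of these halogens comes with a number and the other does not.

Going by these compounds, it remains open how far the entry for compound 3 really lies from the number for compound 4. Also open, on these data alone, is what an amine or a carboxylic acid in place of the halogen on this aromatic carbon would do in this assay.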